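Dropping the catechol hydroxyls from a caffeate ester

A few compounds are considered here, and "the series" means these few. Any claim that something is new, unique, unknown or untested is made for them only; others in the source may bear on it.

Measured so far:
compound 1 `CS(=O)(=O)c1ccc(-c2nc(SCCCOC(=O)/C=C/c3ccc(O)c(O)c3)nn2-c2ccc(Br)cc2)cc1`, 12400 nM
compound 2 `CS(=O)(=O)c1ccc(-c2nc(SCCCOC(=O)/C=C/c3ccc(O)c(O)c3)nn2-c2ccc(F)cc2)cc1`, 10100 nM

Of the compounds shown here, two have been tested in a functional assay on PC-3 cells (Homo sapiens) for antiproliferative activity, read by MTT assay, with a stated time of 72 h; a higher number here means a weaker inhibitor, a lower number a stronger inhibitor. Compound 1 gives 12400 nM, and compound 2 gives 10100 nM. Going by the values given here, of the two numbers, compound 1 carries the higher one, but the single step between them, a 1.2-fold lower number from compound 1 to compound 2 (0.09 log units; within the scatter), does not separate them beyond the scatter, so neither compound can be called the stronger inhibitor on this evidence.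

Compound 3 `CS(=O)(=O)c1ccc(-c2nc(SCCCOC(=O)/C=C/c3ccccc3)nn2-c2ccc(Br)cc2)cc1` differs from compound 1 in a different part of the molecule: phenyl in place of 3,4-dihydroxyphenyl on a double-bonded chain carbon bound to a double-bonded chain carbon. Among the compounds with values here, no measured step touches this part of the structure; the only step available, from compound 1 to compound 2, concerns the halogen on the other aryl ring and was within the scatter. The expectation for compound 3 therefore rests on the value of compound 1 alone, with wide uncertainty. Compound 3 is expected to give 22000 nM in this assay, with a range from 6000 nM to 70000 nM, which corresponds to an estimated step of a 1.8-fold higher number from compound 1 to compound 3 (0.25 log units; within the scatter).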

Compound 3, half-maximal inhibitory concentration: 21900 nM
Compound 3: middle estimate off by 1.0-fold (0.00 log units), on the high side, and the stated range covers the measured number.
By their numbers in this assay, from the lowest: compounds 2, 1 and 3 (each within the scatter of the next, the first and the last beyond it).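

In this assay, phenyl in place of 3,4-dihydroxyphenyl on a double-bonded chain carbon bound to a double-bonded chain carbon gives a 1.8-fold higher number from compound 1 to compound 3 (0.25 log units; within the scatter), so this end of the ester, which the earlier halogen step left untouched, now has a reading of its own, and that reading lies within the scatter. Compound 3 keeps the bromo group of compound 1 but has neither of the two hydroxyl groups, yet the two compounds cannot be told apart here, so in this one pair the 3,4-dihydroxyphenyl group is not shown to be needed for the activity seen in this assay. Nothing given here bears on why this pair reads as it does.

It remains open whether a methoxy group or a single hydroxyl group on this ring would read differently, and whether the same holds with the fluoro group of compound 2, as the pair shown carries bromo. Also open, going by these compounds, is what an amide in place of the ester, or a longer chain in place of the present one, would do to the number in this assay.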